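Swapping the aromatic substituent: from methoxy to acetyl

The compounds below may be only part of what the source reports. "The series", "measured", "known", "first", "only" and "open" are said of these compounds alone.

Compound 1 `CC(C)c1cccc(NC(=O)N[C@H](C)c2ccccc2)c1` and compound 2 `COc1cccc(NC(=O)N[C@H](C)c2ccccc2)c1` share a core and differ only in one group on an aromatic carbon. In an ADME assay on the whole organism with Oryza sativa as the target, tested at 10 uM (a lower number here means a stronger effect, a higher number a weaker effect of the compound at the concentration tested), compound 1 gives 44%, while compound 2 gives 70%. Going by the values given here, compound 2 therefore stands highest of the two numbers measured so far, and the single step of a number 26 percentage points higher from compound 1 to compound 2 (beyond the scatter) shows that changing this one group can shift the read-out by a modest amount beyond the scatter. Compound 3 `CC(=O)c1cccc(NC(=O)N[C@H](C)c2ccccc2)c1` is the next compound, differing from compound 2 as follows: acetyl in place of methoxy on an aromatic carbon. Among the compounds with values here, no measured step matches this change exactly; the only step available shows that a group at this place matters. A step of a number 12 percentage points lower from compound 2 to compound 3 (beyond the scatter) is expected, with wide uncertainty. Compound 3 is estimated at 58%, in the range 35% to 82%.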

Compound 3, a percentage reported as activity, at one concentration (the size of the read-out at that concentration, not a potency): 73%
Compound 3: middle estimate off by 15 percentage points, on the low side; low and high end bracket the measured number.
By their numbers in this assay, from the lowest: compound 1; then compounds 2 and 3 (each within the scatter of the next).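

In this assay, replacing methoxy with acetyl gives a number 3 percentage points higher from compound 2 to compound 3 (within the scatter), so on this aromatic carbon, meta to a large group, the two groups cannot be told apart, even though acetyl brings an extra heavy atom and a double bond. Compound 1 remains the one that stands apart, with a number 29 percentage points higher from compound 1 to compound 3 (beyond the scatter) matching the earlier a number 26 percentage points higher from compound 1 to compound 2 (beyond the scatter) in being beyond the scatter, so the isopropyl compound now differs from two neighbours rather than one. Nothing available explains why methoxy and acetyl read alike or why isopropyl reads differently.

As far as these compounds go, whether an amine, a carboxylic acid or a longer chain at this place would read closer to compound 1 or to compound 2 and compound 3 remains open. So does whether the oxygen shared by methoxy and acetyl matters at all, since three compounds cannot separate it from their other differences.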